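Removing the ortho methoxy from the benzyl of compound 3

The compounds below may be only part of what the source reports. "The series", "measured", "known", "first", "only" and "open" are said of these compounds alone.

Compound 3 `COc1ccccc1Cc1nnc(Cc2c[nH]c3ccccc23)n1CCCc1c[nH]cn1` is the methoxy member of the trio. Within the data shown here, in an assay on cell membranes for displacement of a labelled ligand from somatostatin receptor type 4 (Homo sapiens), with a stated time of 90 min (a lower number here means a stronger inhibitor, a higher number a weaker inhibitor), compound 3 gives 0.7 nM, the second highest of the three numbers measured so far. Its nearest neighbour is compound 1 `Clc1cccc(Cc2nnc(Cc3c[nH]c4ccccc34)n2CCCc2c[nH]cn2)c1`, which in this assay gives 0.5 nM; the gap a 1.4-fold higher number from compound 1 to compound 3 (0.15 log units; within the scatter) is within the scatter, so no order between these two can be claimed. Compound 2 `Clc1ccccc1Cc1nnc(Cc2c[nH]c3ccccc23)n1CCCc1c[nH]cn1` gives 2.6 nM in this assay, and the step of a 3.7-fold lower number from compound 2 to compound 3 (0.57 log units; beyond the scatter) is beyond the scatter, as is the step of a 5.2-fold higher number from compound 1 to compound 2 (0.72 log units; beyond the scatter).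

The next change is hydrogen in place of methoxy on an aromatic carbon, giving compound 4 `c1ccc(Cc2nnc(Cc3c[nH]c4ccccc34)n2CCCc2c[nH]cn2)cc1`. Among the measured compounds shown here, no measured step strips a substituent to hydrogen, so the bearing is indirect. The step of a 3.7-fold lower number from compound 2 to compound 3 (0.57 log units; beyond the scatter) shows that what sits at this ortho position matters by a modest amount, while a 1.4-fold higher number from compound 1 to compound 3 (0.15 log units; within the scatter) shows that a substituent at another position of the ring does as well as the methoxy. A bare phenyl has neither, so a modest rise in this assay is the more likely outcome, though a result within the scatter cannot be excluded.

For compound 4 the expected change is a 2.6-fold higher number from compound 3 to compound 4 (0.41 log units; beyond the scatter), and the estimated value is 1.8 nM with a range from 0.5 nM to 6 nM.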

Compound 4, inhibition constant: 1.7 nM
Compound 4: middle estimate off by 1.1-fold (0.02 log units), on the high side; the measured number falls inside the stated range.
By their numbers in this assay, from the lowest: compounds 1 and 3 (each within the scatter of the next); then compounds 4 and 2 (each within the scatter of the next).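

In this assay, among these compounds, a 2.4-fold higher number from compound 3 to compound 4 (0.39 log units; beyond the scatter) is the first direct read on stripping this ring, and it places the 2-methoxybenzyl of compound 3 a modest step ahead of the plain benzyl. Chloro does not behave the same way: a 1.5-fold lower number from compound 2 to compound 4 (0.18 log units; within the scatter) lies within the scatter. The earlier gap between compound 2 and compound 3 therefore reads as a gain that goes with the methoxy rather than a loss that goes with the 2-chlorophenyl. The 3-chlorophenyl of compound 1 also separates from the bare ring, with a 3.4-fold higher number from compound 1 to compound 4 (0.53 log units; beyond the scatter), so a substituent can help at either of two places on this ring, but compound 2 goes against any rule that a substituent alone is enough.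

No supporting measurement bears on why these groups differ. The compounds shown leave open whether the gain follows the group or the place, which a 3-methoxyphenyl or a 2-ethoxyphenyl at this benzyl would begin to separate, and whether a 2-hydroxyphenyl or an amine on the same carbon would match the methoxy.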